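The compounds below may be only part of what the source reports. "The series", "measured", "known", "first", "only" and "open" are said of these compounds alone.

In a functional assay on SW-620 cells (Homo sapiens) for cytotoxicity, read by MTT assay, with stated times of 4 h and 72 h, tested at 5 uM (a lower number here means a stronger inhibitor, a higher number a weaker inhibitor), compound 1 `Cc1cc(Nc2ccc(C(=O)/C=C/c3ccc4ccccc4c3)cc2)n2nc(SCc3ccccc3)nc2n1` gives 300 nM, compound 2 `Cc1cc(Nc2ccc(C(=O)/C=C/c3ccc4ccccc4c3)cc2)n2nc(SCc3cccc([N+](=O)[O-])c3)nc2n1` gives 790 nM and compound 3 `Cc1cc(Nc2ccc(C(=O)/C=C/c3ccc4ccccc4c3)cc2)n2nc(SCc3cccc(C(F)(F)F)c3)nc2n1` gives 2070 nM, which puts compound 2 in the middle of the three. Compound 4 `Cc1cc(Nc2ccc(C(=O)/C=C/c3ccc4ccccc4c3)cc2)n2nc(SCc3ccccc3[N+](=O)[O-])nc2n1` has not yet been measured. It differs from compound 2 by 2-nitrophenyl in place of 3-nitrophenyl on a saturated chain carbon bound to a sulfur. Among the compounds with values here, no measured step moves the nitro group. The closest evidence is the modest 2.6-fold higher number from compound 1 to compound 2 (0.42 log units; beyond the scatter), with a 2.6-fold higher number from compound 2 to compound 3 (0.42 log units; beyond the scatter) and the larger 6.9-fold higher number from compound 1 to compound 3 (0.84 log units; beyond the scatter) showing how far changes on this ring have gone. With no direction indicated by these steps, no change beyond the scatter is expected in this assay. For compound 4 the expected step is a 1.0-fold higher number from compound 2 to compound 4 (0.01 log units; within the scatter). Compound 4 is estimated at 800 nM, with a range of 280 nM to 2300 nM.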

Compound 4, half-maximal inhibitory concentration: 960 nM
Compound 4: the middle estimate sits 1.2-fold (0.08 log units) below what was measured, within the range that was stated.
By their numbers in this assay, from the lowest: compound 1; then compounds 2 and 4 (each within the scatter of the next); then compound 3.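

In the assay (this assay), 2-nitrophenyl in place of 3-nitrophenyl on a saturated chain carbon bound to a sulfur stays within the scatter (a 1.2-fold higher number from compound 2 to compound 4 (0.08 log units; within the scatter)), so this nitro move makes no clear difference. The number stays higher than with the unsubstituted phenyl (a 3.2-fold higher number from compound 1 to compound 4 (0.51 log units; beyond the scatter)) and lower than with 3-(trifluoromethyl)phenyl (a 2.2-fold lower number from compound 3 to compound 4 (0.33 log units; beyond the scatter)). Nothing measured here explains these numbers. On these data alone, it remains open whether 2-(trifluoromethyl)phenyl would follow the nitro pair. An aminophenyl group, or a longer chain in place of the benzyl link, is also untested in what is shown.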